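The compounds below may be only part of what the source reports. "The series", "measured", "known", "first", "only" and "open" are said of these compounds alone.

Measured so far in an ADME assay on microsomes from liver (Homo sapiens) for metabolic stability, read by LC-MS, with NADPH named in the record, with a stated time of 60 min, tested at 1 uM, in the absence of a further agent; on this read-out higher numbers stand for a more stable compound and lower numbers for a less stable compound:
Compound 1 `COc1ccc(-c2c(C)nc3c(N4CC[C@@H](NC(C)=O)C4)cc(C)nn23)cc1OC`: > 95%
Compound 2 `COc1ccc(-c2c(C)nc3c(N4CC[C@@H](NS(=O)(=O)c5ccc(C(C)=O)cc5)C4)cc(C)nn23)cc1OC`: > 95%

Compound 1 gives > 95%, which is a limit of the assay and not a number. Compound 2 gives > 95%, which is also a limit. Together they show (the limit of > 95% in this assay, at which 2 of the 2 values shown sit), so the true stability of compound 1 stays hidden.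

Compound 3 `COc1ccc(-c2cnc3c(N4CC[C@@H](NC(C)=O)C4)cc(C)nn23)cc1OC` has not been measured yet. It differs from compound 1 by hydrogen in place of methyl on an aromatic carbon of a five-membered aromatic ring with 2 nitrogen.

Among the measured compounds shown here, the only measured step is a step that the two limits leave unreadable from compound 1 to compound 2, where (4-acetylphenyl)sulfonyl stands in place of acetyl on an amine nitrogen. That step lies elsewhere in the molecule and has no readable size, so it offers only weak guidance. For the measured compounds named here, no measured step touches the methyl itself. Still, compound 3 carries a far smaller change than compound 2, and in this assay compound 2 gives > 95%. On that slim basis, the estimated step of a number at least 3 percentage points lower from compound 1 to compound 3 (that floor lies within the scatter) is expected to stay within the usual scatter, and no clear direction is expected. Compound 3 is expected at 92%, with an estimated range from 78% to 100%.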

Compound 3, percent of the compound remaining: > 95%
Compound 3 was reported as a limit; the forecaster's own chance of this, stated with the estimate: 50%; middle value at least 3 percentage points away from the limit.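

In this assay compound 3 gives > 95% as a limit of the assay and not a number. Compound 1 also sits at a limit, so the step between compound 1 and compound 3 cannot be read: the limit of > 95% in this assay, at which 3 of the 3 values shown sit. Going by these compounds, what stays open is how stable these compounds truly are, and whether hydrogen in place of methyl changes that stability at all.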